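The source may hold more compounds than are shown below. What is called first, only, known or untested is meant among the compounds shown, and "the series" means these compounds.

Compound 1 `COC(=O)c1ccc(OCC2SCCN2C(=O)Cn2ccnc2)cc1` gives 62 mg/kg
Compound 2 `C=CC(=O)N1CCSC1COc1ccccc1OC` gives 74 mg/kg
Compound 3 `CCOC(=O)CC(=O)N1CC[S+]([O-])C1COc1ccccc1OC` gives 27 mg/kg

In a functional assay on the whole organism for inhibition, with Cavia porcellus as the target (on this read-out higher numbers stand for an effect only at larger amounts of compound and lower numbers for an effect already at smaller amounts), compound 2 gives 74 mg/kg and shares the top of the range with compound 1 at 62 mg/kg as the two lie within the scatter of each other. Compound 2 needs a larger dose than compound 3 at 27 mg/kg and that gap lies beyond the scatter.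

Compound 4 `CNC(=O)CC(=O)N1CCSC1COc1ccccc1OC` has not been measured yet. Set against compound 2 it carries (methylcarbamoyl)methyl in place of vinyl on a carbonyl carbon as the counted difference. Among the compounds with values here, no measured pair shows this change alone, so only the narrow spread of the three values guides the expectation. In this assay the expected 1.6-fold lower number from compound 2 to compound 4 (0.22 log units; within the scatter) is small, towards a smaller dose, and not beyond the scatter. For compound 4 the estimate is 45 mg/kg with an expected range from 18 mg/kg to 110 mg/kg in this read-out.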

Compound 4, dose for half-maximal effect: 21 mg/kg
Compound 4: the middle estimate sits 2.1-fold (0.33 log units) above what was measured, and the stated range covers the measured number.
By their numbers in this assay, from the lowest: compounds 4 and 3 (each within the scatter of the next); then compounds 1 and 2 (each within the scatter of the next).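

In this assay, within the data shown here, putting (methylcarbamoyl)methyl in place of vinyl on a carbonyl carbon gives a 3.5-fold lower number from compound 2 to compound 4 (0.55 log units; beyond the scatter) and so shows, for the first time in a single-change pair, that the group at this place affects the dose needed. The entering group counts one hydrogen-bond donor and one acceptor, while vinyl counts neither, and it also has more heavy atoms. Nothing available explains the shift.

As far as these compounds go, whether the amide hydrogen matters remains open, since this one pair cannot separate it from the larger group. From the compounds shown here alone, how an amine, a carboxylic acid or a longer chain would behave at this place also remains open.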